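Triazolopyrimidine series: ortho-chloro on the benzyl group

This account rests on a few compounds, and the source may have more. Where it says the series, first, only, none or still open, it means among the compounds named here.

Measured compounds in an assay on Cerebral cortex for displacement of a labelled ligand from adenosine receptor A1 (Bos taurus); a lower number here means a stronger inhibitor, a higher number a weaker inhibitor:
- compound 1, `CNc1nc(-c2ccccc2)nc2c1nnn2Cc1ccccc1`, gives 353 nM
- compound 2, `CNc1nc(-c2ccccc2)nc2c1nnn2Cc1ccccc1Cl`, gives 191 nM
- compound 3, `OCCNc1nc(-c2ccccc2)nc2c1nnn2Cc1ccccc1`, gives 38 nM

Compound 3 holds the lowest of the three numbers, and its gaps to compound 1 and to compound 2 are both beyond the scatter. The two cores differ as described by hydroxymethyl in place of hydrogen on a saturated chain carbon bound to a nitrogen on an aromatic ring; this change gives a 9.3-fold lower number from compound 1 to compound 3 (0.97 log units; beyond the scatter), a modest but real gain.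

The change chloro in place of hydrogen on an aromatic carbon is seen once with measured values: it gives a 1.8-fold lower number from compound 1 to compound 2 (0.27 log units; within the scatter), a step that stays within the scatter, so compound 1 and compound 2 cannot be ordered with confidence.

Compound 4, `OCCNc1nc(-c2ccccc2)nc2c1nnn2Cc1ccccc1Cl`, has not yet been measured in this assay. It carries the change chloro in place of hydrogen on an aromatic carbon on the core of compound 3. Within the data shown here, the place of this change is worded identically to the one between compound 1 and compound 2, so it is the same change placed on a different core.

For compound 4 the step is expected to be about a 1.5-fold lower number from compound 3 to compound 4 (0.18 log units; within the scatter), set beside the measured one, because a 1.8-fold lower number from compound 1 to compound 2 (0.27 log units; within the scatter) lay within the scatter and no listed compound shows the chloro behaving differently on the hydroxyethyl core. Compound 4 is therefore estimated at 25 nM in this assay, with a likely range from 10 nM to 60 nM.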

Compound 4, inhibition constant: 116 nM
Compound 4: the middle estimate sits 4.6-fold (0.67 log units) below what was measured, and the stated range ends below it.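

On the core of compound 3 in this assay, benzyl to 2-chlorobenzyl gives a 3.1-fold higher number from compound 3 to compound 4 (0.48 log units; beyond the scatter) and so does not repeat the result on the core of compound 1, where the step stayed within the scatter; the change does not carry over unaltered between these two cores: the same change on two cores in this assay, a 1.8-fold lower number (0.27 log units; within the scatter) from compound 1 to compound 2 and a 3.1-fold higher number (0.48 log units; beyond the scatter) from compound 3 to compound 4, 5.6-fold (0.75 log units) apart, beyond the scatter of two such steps.

Seen from the other direction, the step for hydroxymethyl in place of hydrogen on the chain is a 1.6-fold lower number from compound 2 to compound 4 (0.22 log units; within the scatter) and leaves the two chloro compounds unordered, whereas the same change gave a clear gain without the chloro: the same change on two cores in this assay, a 9.3-fold lower number (0.97 log units; beyond the scatter) from compound 1 to compound 3 and a 1.6-fold lower number (0.22 log units; within the scatter) from compound 2 to compound 4, 5.6-fold (0.75 log units) apart, beyond the scatter of two such steps.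

Both comparisons rest on the same four compounds and show that the two changes do not act independently in this set, but they do not establish a rule for the wider series or show why the changes interact.

From the compounds shown here alone, it remains open whether the reversal belongs to chloro in particular or would also appear with fluoro, methyl or methoxy in the same place on the benzyl group. Going by these compounds, it is also open whether a longer chain or an amine in place of the hydroxyethyl group would behave like compound 3 or like compound 1 when the 2-chlorobenzyl group is present.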